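The source may hold more compounds than are shown below. What is called first, only, known or untested is meant among the compounds shown, and "the series" means these compounds.

The study compares three measured compounds and one still unmeasured in a functional assay on QGY7701 cells (Homo sapiens) for cytotoxicity, read by MTT assay, with a stated time of 24 h; a higher number here means a weaker inhibitor, a lower number a stronger inhibitor. Compound 1 `C=CC1=C(C(=O)Nc2ccccc2OC)C(c2ccc(F)cc2)OC1` carries a 2-methoxyphenyl on the amide-type nitrogen, and in this assay compound 1 gives 52800 nM. Compound 2 `C=CC1=C(C(=O)NCc2ccccc2F)C(c2ccc(F)cc2)OC1` carries a 2-fluorobenzyl on that nitrogen instead, and compound 2 gives 51400 nM. The two differ only by 2-methoxyphenyl in place of 2-fluorobenzyl on an amide-type nitrogen, and the step from compound 2 to compound 1 is a 1.0-fold higher number from compound 2 to compound 1 (0.01 log units; within the scatter). Compound 3 `C=CC1=C(C(=O)NCc2ccccc2F)C(c2ccc(OC)cc2)OC1` keeps the 2-fluorobenzyl, but its core differs from the core of compound 2 by methoxy in place of fluoro on an aromatic carbon. For compound 3 this assay reports only a limit, > 100000 nM. The step from compound 2 to compound 3 is therefore an at least 1.9-fold higher number from compound 2 to compound 3 (0.28 log units; that floor lies within the scatter).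

Compound 4 `C=CC1=C(C(=O)Nc2ccccc2OC)C(c2ccc(OC)cc2)OC1` has not yet been measured. It differs from compound 3 by 2-methoxyphenyl in place of 2-fluorobenzyl on an amide-type nitrogen, the same change as that made between compound 2 and compound 1, here made on the core of compound 3. Because the earlier pair showed a 1.0-fold higher number from compound 2 to compound 1 (0.01 log units; within the scatter), for compound 4 the expected step is a step that the limit leaves unreadable from compound 3 to compound 4. Since compound 3 already sits at the limit of > 100000 nM in this assay, at which 1 of the 3 values shown sits, compound 4 is expected to return a limit as well, and its estimated value in this assay is 150000 nM, in a range from 70000 nM to 400000 nM.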

Compound 4, half-maximal inhibitory concentration: > 100000 nM
Compound 4 gave a limit, no number (the forecaster's own chance of this, stated with the estimate: 70%); the middle value does not contradict the limit.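

In this assay compound 4 gives only a limit of the assay, not a number: > 100000 nM. Methoxy in place of fluoro on an aromatic carbon, now carried onto the core bearing the 2-methoxyphenyl, gives an at least 1.8-fold higher number from compound 1 to compound 4 (0.27 log units; that floor lies within the scatter), while the step for 2-methoxyphenyl in place of 2-fluorobenzyl on the core with the methoxy cannot be read, as both of its ends are limits. Set beside the earlier case, this does not show that the methoxy change moves the number on either core, since each floor lies within the scatter, nor does it show that the change carries over from one core to the other with the same size: the same change on two cores in this assay, an at least 1.9-fold higher number (0.28 log units; that floor lies within the scatter) from compound 2 to compound 3 and an at least 1.8-fold higher number (0.27 log units; that floor lies within the scatter) from compound 1 to compound 4; the limit leaves it open whether they differ.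

Going by these compounds, how far the two methoxy compounds really lie from the others stays open, as neither has a number of its own in this assay: the limit of > 100000 nM in this assay, at which 2 of the 4 values shown sit. Also open, on these data alone, is what an amine or a carboxylic acid would give in place of the fluoro or methoxy on that aromatic carbon, and what a longer chain would give on the amide-type nitrogen.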